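The source may hold more compounds than are shown below. What is called first, only, known or untested is meant among the compounds shown, and "the series" means these compounds.

Compound 1 `COc1ccc2c(c1)OC(c1cc(OC)c(OC)c(OC)c1)C(CO)=C2` — > 50000 nM
Compound 2 `COc1ccc2c(c1)OC(c1cc(OC)c(OC)c(OC)c1)C(C(=O)N(C)OC)=C2` — 11700 nM
Compound 3 `COc1ccc2c(c1)OC(c1cc(OC)c(OC)c(OC)c1)C(C(=O)O)=C2` — > 50000 nM

All three share one core and differ only in the group on the double-bonded ring carbon. In a functional assay for inhibition of nuclear factor NF-kappa-B complex (Homo sapiens) (on this read-out higher numbers stand for weaker inhibition and lower numbers for stronger inhibition), compound 1 reaches only > 50000 nM, which is a limit of the assay and not a number. Compound 3, the carboxy analogue, likewise stops at a limit, so compound 1 and compound 3 both sit at the limit of > 50000 nM in this assay, at which 2 of the 3 values shown sit. Compound 2 alone gives a real number, 11700 nM, so compound 1 stands at the weak end of what is shown, with no number of its own.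

The unmeasured compound 4 `CNC(=O)C1=Cc2ccc(OC)cc2OC1c1cc(OC)c(OC)c(OC)c1` changes compound 1 in one place: methylcarbamoyl in place of hydroxymethyl on a double-bonded ring carbon. This resembles the move to compound 2, where the step was an at least 4.2-fold lower number from compound 1 to compound 2 (0.63 log units; beyond the scatter), while the acid gave an at least 4.2-fold higher number from compound 2 to compound 3 (0.63 log units; beyond the scatter) in the other direction. Compound 4 carries an amide like compound 2, so a step of similar kind is expected in this assay, an at least 2.5-fold lower number from compound 1 to compound 4 (0.39 log units; beyond the scatter), though perhaps smaller. Compound 4 is therefore expected to give about 20000 nM, within 6000 nM to 60000 nM.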

Compound 4, half-maximal inhibitory concentration: > 50000 nM
Compound 4 gave a limit, no number; the forecaster's own chance of this, stated with the estimate: 40%; middle value at least 2.5-fold (0.39 log units) away from the limit.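

Compound 4 also carries an amide on the double-bonded ring carbon, yet in this assay compound 4 stops at > 50000 nM, which is a limit of the assay and not a number. An amide carbonyl at this position is therefore not enough for a measurable value: with hydrogen in place of methoxy on the amide-type nitrogen, the result is an at least 4.2-fold higher number from compound 2 to compound 4 (0.63 log units; beyond the scatter), so this one change on the nitrogen, far from the core, separates a real number from a limit. Compound 2 remains the only compound of the four with a real number, while compound 1, compound 3 and compound 4 share one reading: the limit of > 50000 nM in this assay, at which 3 of the 4 values shown sit.

The steps among compound 1, compound 3 and compound 4 cannot be read, so any order among these three stays unknown. Also open, going by these compounds, is whether the methoxy on the nitrogen is needed as such or whether a second group of another kind would serve: a dimethylcarbamoyl group, with methyl in its place, would test the first, and a methoxycarbamoyl group, with hydrogen in place of the nitrogen's methyl, would test whether that methyl is needed.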